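Replacing 1,3-benzothiazol-5-yl with 1H-indazol-5-yl: what to expect

A few compounds are considered here, and "the series" means these few. Any claim that something is new, unique, unknown or untested is made for them only; others in the source may bear on it.

Of the compounds shown here, three sharing one core have been measured in an ADME assay (liver) for metabolic stability, with Liver microsome (Homo sapiens) as the target, using microsomes and NADPH, with a stated time of 30 min, tested at 1 uM; a lower number here means slower removal, a higher number faster removal of the compound. Compound 1 `Nc1ccc(S(=O)(=O)N2CCN(c3ncc(C(O)(C(F)(F)F)C(F)(F)F)cc3-c3ccccc3O)CC2)cn1` gives 22 mL.min-1.g-1, compound 2 `COc1ccc(-c2cc(C(O)(C(F)(F)F)C(F)(F)F)cnc2N2CCN(S(=O)(=O)c3ccc(N)nc3)CC2)cn1` gives 25 mL.min-1.g-1 and compound 3 `Nc1ccc(S(=O)(=O)N2CCN(c3ncc(C(O)(C(F)(F)F)C(F)(F)F)cc3-c3ccc4scnc4c3)CC2)cn1` gives 39 mL.min-1.g-1. Compound 3 therefore stands within the usual scatter of both other compounds, and these numbers cannot rank the three.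

Compound 4 `Nc1ccc(S(=O)(=O)N2CCN(c3ncc(C(O)(C(F)(F)F)C(F)(F)F)cc3-c3ccc4[nH]ncc4c3)CC2)cn1` carries 1H-indazol-5-yl in place of 1,3-benzothiazol-5-yl on an aromatic carbon. The measured steps that bear on this change are swaps of the group at that same place, and all are small in this assay: a 1.1-fold higher number from compound 1 to compound 2 (0.06 log units; within the scatter), a 1.8-fold higher number from compound 1 to compound 3 (0.25 log units; within the scatter) and a 1.6-fold higher number from compound 2 to compound 3 (0.19 log units; within the scatter). None of them involves 1H-indazol-5-yl, so this remains an extrapolation, but these three steps give no reason to expect a large change. The expected step is a 1.3-fold lower number from compound 3 to compound 4 (0.11 log units; within the scatter), which would not stand out from the scatter. For compound 4 the estimated value is 30 mL.min-1.g-1, with an expected range from 16 mL.min-1.g-1 to 55 mL.min-1.g-1.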

Compound 4, intrinsic clearance in microsomes: 27 mL.min-1.g-1
The estimate for compound 4 lay 1.1-fold (0.05 log units) above the measured number; the range from low to high includes it.
By their numbers in this assay, from the lowest: compounds 1, 2, 4 and 3 (each within the scatter of the next).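

In this assay, 1H-indazol-5-yl, a fourth aromatic group at this place on the shared core, stays within the scatter of all three earlier compounds (a 1.4-fold lower number from compound 3 to compound 4 (0.16 log units; within the scatter); a 1.1-fold higher number from compound 2 to compound 4 (0.03 log units; within the scatter); a 1.2-fold higher number from compound 1 to compound 4 (0.09 log units; within the scatter)). This change swaps a group with 0 hydrogen-bond donors for one with 1 hydrogen-bond donor, at the same count of heavy atoms and with sulfur giving way to nitrogen, and the read-out does not move beyond the scatter, so the four compounds still cannot be ranked. No measurement is available that could explain this result.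

From the compounds shown here alone, all four groups at this place are aromatic, so it remains open whether a non-aromatic group, such as a simple amine or a carboxylic acid, would give a step beyond the scatter. Going by these compounds, it is also open whether a methyl group on the indazole nitrogen would change the number.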